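The source may report more compounds than this note shows. Statements on the series, on what has been measured and on what is new or still open speak of the compounds shown alone.

Measured in a physicochemical assay for lipophilicity, at pH 7.4; a higher number here means a more lipophilic compound, a lower number a more polar compound:
- compound 1 `CCc1ccc(N(CC(C)C)S(=O)(=O)c2ccc3cc(OCC4CCOCC4)c(C(=O)O)cc3c2)cc1`: 1.77
- compound 2 `Cc1ccc(NS(=O)(=O)c2ccc3c(c2)C(=O)CC(C2CCOCC2)O3)c(C)c1`: 2.75
- compound 3 `CC(C)CN(Cc1ccccc1C(F)(F)F)S(=O)(=O)c1ccc2c(c1)C(=O)CC(C1CCOCC1)O2`: 4.32

Compound 1 has the lowest number of the three in this assay. Compound 2 lies nearest to it and compound 3 furthest, and both gaps are beyond the usual scatter.

The next compound, compound 4 `CCc1ccc(N(CC(C)C)S(=O)(=O)c2ccc3cc(OCC4CCOCC4)c(CO)cc3c2)cc1`, has not yet been measured. It differs from compound 1 in one place: hydroxymethyl in place of carboxy on an aromatic carbon. Hydroxymethyl stands in place of carboxy on an aromatic carbon, ortho to a (oxan-4-yl)methoxy group.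

Within the data shown here, no measured pair isolates this change, so its size can only be judged loosely. Among the measured compounds shown here, compound 1 is the only measured compound with a carboxy group, and neither compound 2 at 2.75 nor compound 3 at 4.32 carries one. These two also differ from compound 1 elsewhere, but a large upward step, well beyond the scatter, is still expected. The expected change is a number 2.43 log units higher from compound 1 to compound 4 (beyond the scatter). For compound 4 the estimated value is 4.2, with an expected range from 3.4 to 5.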

Compound 4, distribution coefficient: 5.1
Estimate against measurement, compound 4: 0.90 log units below; the measured number lies above the stated range.
By their numbers in this assay, from the lowest: compound 1; then compound 2; then compound 3; then compound 4.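

In this assay, among these compounds, replacing carboxy with hydroxymethyl on this aromatic carbon, ortho to a (oxan-4-yl)methoxy group, gives a number 3.33 log units higher from compound 1 to compound 4 (beyond the scatter), the first step in this set that can be assigned to a single place. Among the compounds shown here, each group carries 1 hydrogen-bond donor and 1 hydrogen-bond acceptor, so the step appears with those counts unchanged, and the earlier compounds, which also differ from compound 1 elsewhere, could not show this. Nothing measured here accounts for the size of the step.

Going by these compounds, whether a methyl ester, a primary amide or an aminomethyl group at this carbon would fall nearer compound 1 or compound 4 remains open. On these data alone, it is also open whether a step of this size would recur on a core other than that of compound 1.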